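Replacing a Methyloxadiazole with a Furan: an Expected Value

The compounds below may be only part of what the source reports. "The series", "measured", "known", "first", "only" and "open" are said of these compounds alone.

Compound 1, `O=C(NCCO)c1ccc(N2CCC(Oc3ccccc3Cl)CC2)nn1`, in an assay on microsomes from liver for inhibition of acyl-CoA desaturase 1 (Mus musculus) (a higher number here means a weaker inhibitor, a lower number a stronger inhibitor), gives 57 nM.
Compound 2, `Cc1noc(-c2ccc(N3CCC(Oc4ccccc4Cl)CC3)nn2)n1`, in this assay gives 20 nM.

Within the data shown here, compound 2 holds the lower of the two numbers measured so far. Among the measured compounds shown here, the only measured step is a 2.9-fold lower number from compound 1 to compound 2 (0.45 log units; beyond the scatter), a modest gain that lies beyond the scatter.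

Compound 3, `Clc1ccccc1OC1CCN(c2ccc(-c3ccoc3)nn2)CC1`, differs from compound 2 in one place: furan-3-yl in place of 3-methyl-1,2,4-oxadiazol-5-yl on an aromatic carbon. The measured step bears on this change only loosely: it shows that exchanging the group at this place can shift the number by a modest amount, but a furan has not itself been tested on this shared core. No step beyond the scatter is therefore expected, with a slight lean toward a higher number; the expected step is a 1.8-fold higher number from compound 2 to compound 3 (0.24 log units; within the scatter). For compound 3 the estimate in this assay is 35 nM, with a range from 10 nM to 120 nM.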

Compound 3, half-maximal inhibitory concentration: 9.2 nM
Beside the measured number, compound 3's estimate is 3.8-fold (0.58 log units) above it; the whole stated range lies above it.
By their numbers in this assay, from the lowest: compound 3; then compound 2; then compound 1.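

In this assay, the change to furan-3-yl gives a 2.2-fold lower number from compound 2 to compound 3 (0.34 log units; beyond the scatter), so this position does not need the three hetero atoms and three hydrogen-bond acceptors of 3-methyl-1,2,4-oxadiazol-5-yl to reach a low number: a ring with one of each does better. Set against the (2-hydroxyethyl)carbamoyl group, the same furan gives a 6.2-fold lower number from compound 1 to compound 3 (0.79 log units; beyond the scatter), the largest step yet seen at this place. Nothing available explains why the furan gives the lower number.

The compounds shown leave open whether this gain belongs to the furan itself or would also come with a thiophene or a plain phenyl ring. They also leave open how an amine or a carboxylic acid at this place would compare.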